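Chain extension on two related phenyl-bearing cores

The source may hold more compounds than are shown below. What is called first, only, known or untested is meant among the compounds shown, and "the series" means these compounds.

Compound 1 `CCCCCCCCCCCCCCCCNC(=O)c1c[nH]c(-c2ccccc2)n1` and compound 2 `CCCCCCCCCCCCCCCCCCNC(=O)c1c[nH]c(-c2ccccc2)n1` share one core and differ only in chain length; compound 3 `CCCCCCCCCCCCCCCCNC(=O)[C@@H]1CNC(c2ccccc2)=N1` and compound 4 `CCCCCCCCCCCCCCCCCCNC(=O)[C@@H]1CNC(c2ccccc2)=N1` share a second core and differ in the same way. The difference between the two cores is not broken down here.

In a functional assay on B16-F1 cells (Mus musculus) for antiproliferative activity, read by sulforhodamine B assay, with a stated time of 48 h (on this read-out lower numbers stand for stronger inhibition and higher numbers for weaker inhibition), compound 1 gives 39700 nM. For compound 2 the result is a limit of the assay, > 30000 nM. The change from compound 1 to compound 2 is ethyl in place of hydrogen on a saturated chain carbon, ten or more bonds along the chain from an amide-type nitrogen, and the step it made, a step that the limit leaves unreadable from compound 1 to compound 2, cannot be sized because the limit of > 30000 nM in this assay, at which 1 of the 3 values shown sits, hides the end point. Compound 3 gives 5700 nM in this assay, a lower number than compound 1, and that gap lies beyond the scatter of repeated measurements.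

For the measured compounds named here, the change from compound 3 to compound 4 is ethyl in place of hydrogen on a saturated chain carbon, ten or more bonds along the chain from an amide-type nitrogen, the same change as the one from compound 1 to compound 2, at the same place on the chain. The only precedent for it among these compounds is unreadable, so no direction can be taken from it; the expectation rests mainly on compound 3 and its value 5700 nM, with a wide allowance for the step. Compound 4 is expected to fall near 9000 nM, a step of a 1.6-fold higher number from compound 3 to compound 4 (0.20 log units; within the scatter), with a range from 3000 nM to 27000 nM.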

Compound 4, half-maximal inhibitory concentration: 50500 nM
The estimate for compound 4 lay 5.6-fold (0.75 log units) below the measured number, outside the stated range (above it).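

On the core of compound 3, ethyl in place of hydrogen on a saturated chain carbon, ten or more bonds along the chain from an amide-type nitrogen, gives an 8.9-fold higher number from compound 3 to compound 4 (0.95 log units; beyond the scatter) in this assay, so inhibition is weaker with the change on this core. The same change on the core of compound 1 cannot be read, because compound 2 stands at a limit of the assay and not at a number: the limit of > 30000 nM in this assay, at which 1 of the 4 values shown sits. The series therefore holds one readable step on one core, which shows what the change does there but not whether its size, or even its direction, carries over from one core to the other.

From the compounds shown here alone, how a shorter or a longer chain would read on either core remains open, so a single step on the core of compound 3 cannot be called a trend. Also open, going by these compounds, is whether an amine or a carboxylic acid in place of the ethyl, at the same place on the chain, would read differently on the two cores, and any comparison of the cores needs a step on the core of compound 1 that ends in a number.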